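Swapping cyano for nitro on compound 3

A few compounds are considered here, and "the series" means these few. Any claim that something is new, unique, unknown or untested is made for them only; others in the source may bear on it.

In a functional assay on LNCaP cells (Homo sapiens) for antiproliferative activity, read by propidium iodide staining, with a stated time of 96 h (on this read-out lower numbers stand for stronger inhibition and higher numbers for weaker inhibition), compound 1 `CC(O)(COc1cccc(S(F)(F)(F)(F)F)c1)C(=O)Nc1ccc(C#N)c(C(F)(F)F)c1` gives 9800 nM and compound 2 `CC(O)(COc1ccc(C(F)(F)F)cc1)C(=O)Nc1cccc(S(F)(F)(F)(F)F)c1` gives 9600 nM with no gap beyond the scatter. Compound 3 `CC(O)(CS(=O)(=O)c1ccc(S(F)(F)(F)(F)F)cc1)C(=O)Nc1ccc(C#N)cc1C(F)(F)F` gives 17800 nM and stands within the scatter of both. Among the measured compounds shown here, compound 4 `CC(O)(CS(=O)(=O)c1ccc(S(F)(F)(F)(F)F)cc1)C(=O)Nc1ccc([N+](=O)[O-])cc1C(F)(F)F` keeps the rest of compound 3 and carries nitro in place of cyano on an aromatic carbon as its only change. For the measured compounds named here, no measured pair shows this swap, so the expectation rests on compound 3 at 17800 nM alone. No step beyond the scatter is expected in this assay for this change. The estimated step of a 1.2-fold lower number from compound 3 to compound 4 (0.07 log units; within the scatter) is therefore small. Compound 4 is expected at 15000 nM with an estimated range from 7000 nM to 32000 nM around that figure.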

Compound 4, half-maximal inhibitory concentration: 12500 nM
Beside the measured number, compound 4's estimate is 1.2-fold (0.08 log units) above it, within the range that was stated.
By their numbers in this assay, from the lowest: compounds 2, 1, 4 and 3 (each within the scatter of the next).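

In this assay, nitro in place of cyano on this aromatic carbon, meta to a trifluoromethyl group and para to a large group, gives a 1.4-fold lower number from compound 3 to compound 4 (0.15 log units; within the scatter). Among the compounds shown here, this is the first single-place step, and it shows that this swap does not move the number beyond the scatter on the core of compound 3. Nothing available explains this result. From the compounds shown here alone, what remains open is whether an amine or a carboxylic acid at this position would also stay within the scatter of compound 3, and whether the same swap would hold on the core of compound 1.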